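The compounds below may be only part of what the source reports. "The series", "measured", "known", "first", "only" and "open" are said of these compounds alone.

Compound 1, `Cc1[nH]nc(N)c1-c1ccc2ccccc2c1`, a limit in an assay on Sf9 cells for inhibition of mitogen-activated protein kinase kinase kinase 14 (Homo sapiens), read by ADP-Glo, with a stated time of 60 min (a lower number here means a stronger inhibitor, a higher number a weaker inhibitor), of > 100000 nM.
Compound 2, `Cc1cccc(-c2c(N)n[nH]c2C)c1`, a limit of > 100000 nM.
Compound 3, `Cc1[nH]nc(N)c1-c1cccc(Br)c1`, a limit of > 100000 nM.

Each of these three values is a limit of this assay, not a measured number: the compounds showed no inhibition up to the highest concentration tested. Compound 2 therefore stands only at a limit, and the same holds for the two other values shown. The shared core carries an aryl group, and the compounds differ only in what sits on that aryl ring.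

Within the data shown here, the one step that connects two measured compounds is a step that the two limits leave unreadable from compound 2 to compound 3. Both ends of that step are limits, so its size cannot be read, and it gives no guide to how a change on the aryl ring moves potency.

Compound 4, `Cc1[nH]nc(N)c1-c1cccc(C(F)(F)F)c1`, is not yet measured. It differs from compound 2 by trifluoromethyl in place of methyl on an aromatic carbon. Among the measured compounds shown here, no measured step bears on this change in a readable way; the only fact to lean on is the limit of > 100000 nM in this assay, at which 3 of the 3 values shown sit, with all three values sitting there. Compound 4 is therefore expected to sit at or near that limit as well, with the step from compound 2 estimated as a number no higher from compound 2 to compound 4 (the limit leaves the size open). The estimate for compound 4 in this assay is 100000 nM, in a range from 20000 nM to 300000 nM.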

Compound 4, half-maximal inhibitory concentration: > 100000 nM
Compound 4 was reported as a limit (the forecaster's own chance of this, stated with the estimate: 85%); the middle value sits exactly at the limit.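

In this assay compound 4 gives > 100000 nM, which is a limit and not a number. The steps to compound 4 from compound 2 and from compound 3 join limit to limit and cannot be read, and what remains is this: the limit of > 100000 nM in this assay, at which 4 of the 4 values shown sit. The compounds shown leave open whether any change on the aryl ring can bring measurable inhibition.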